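A Second Phenyl on Compound 1

The source may report more compounds than this note shows. Statements on the series, on what has been measured and on what is new or still open speak of the compounds shown alone.

For the measured compounds named here, in a functional assay on a cell-free system (plasma, Homo sapiens) for inhibition, with Plasma (Rattus norvegicus) as the target (on this read-out higher numbers stand for weaker inhibition and lower numbers for stronger inhibition), compound 1 (`Cc1c(OCc2ccccc2)ccc2c(N3CCNCC3)cc(=O)oc12`) gives 1100 nM, the lower of the two numbers so far, and compound 2 (`CSCOc1ccc2c(N3CCNCC3)cc(=O)oc2c1C`) gives 3400 nM. Compound 3 (`Cc1c(OCc2ccccc2-c2ccccc2)ccc2c(N3CCNCC3)cc(=O)oc12`) differs from compound 1 by phenyl in place of hydrogen on an aromatic carbon. Going by the values given here, only one measured step bears on this change, and only indirectly: a 3.1-fold higher number from compound 1 to compound 2 (0.49 log units; beyond the scatter), which replaces the phenyl that compound 3 extends. No step beyond the scatter is therefore expected, and the expected change is a 1.2-fold lower number from compound 1 to compound 3 (0.09 log units; within the scatter). Compound 3 is estimated at 900 nM, with an expected range of 300 nM to 2800 nM.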

Compound 3, half-maximal inhibitory concentration: 23000 nM
The estimate for compound 3 lay 26-fold (1.41 log units) below the measured number; measured number outside the range, above it.
By their numbers in this assay, from the lowest: compound 1; then compound 2; then compound 3.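

In this assay, phenyl in place of hydrogen on an aromatic carbon, ortho to a large group, brings a 21-fold higher number from compound 1 to compound 3 (1.32 log units; beyond the scatter) and so marks this place on the ring as one where adding phenyl costs much inhibition. The earlier compounds shown here showed only what replacing the whole phenyl does, not what adding to it does. Nothing at hand accounts for the size of this step.

On these data alone, whether methyl, fluorine or an amine at the same carbon would keep the number near that of compound 1 stays open. So does whether phenyl on another carbon of that ring would bring a step of similar size.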